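Piperidine dienamide and trienamide series: dimethylamino variant

This account rests on a few compounds, and the source may have more. Where it says the series, first, only, none or still open, it means among the compounds named here.

Measured so far:
compound 1, `COc1ccc(/C=C/C=C/C=C/C(=O)N2CCCCC2)cc1`: 1.08%
compound 2, `COc1cc(/C=C/C=C/C(=O)N2CCCCC2)ccc1O`: 55.5%

In an assay for inhibition of Polyunsaturated fatty acid 5-lipoxygenase (Homo sapiens), read by spectrophotometry, tested at 20 uM (on this read-out higher numbers stand for more inhibition at the one concentration tested (going by the name of the read-out) and lower numbers for less inhibition), compound 1 gives 1.08%, the lower of the two numbers recorded. Compound 2 gives 55.5% in this assay, a number higher than that of compound 1 by more than the usual scatter; the two structures differ in several places, so the gap is simply noted.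

Compound 3, `CN(C)c1ccc(/C=C/C=C/C=C/C(=O)N2CCCCC2)cc1`, carries the change (dimethylamino in place of methoxy on an aromatic carbon). Within the data shown here, no single-change pair has yet been measured, so the step from compound 1 to compound 3 is expected to be small, a number 6.9 percentage points higher from compound 1 to compound 3 (within the scatter), likely within the scatter. Compound 3 is therefore estimated at 8%, with a range from 0% to 30%.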

Compound 3, a percentage reported as inhibition, at one concentration (the size of the read-out at that concentration, not a potency): 27.4%
Beside the measured number, compound 3's estimate is 19.4 percentage points below it; low and high end bracket the measured number.
By their numbers in this assay, from the lowest: compound 1; then compound 3; then compound 2.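

With dimethylamino in place of methoxy on the aromatic carbon para to a large group, this assay gives a number 26.3 percentage points higher from compound 1 to compound 3 (beyond the scatter). Among these compounds, this is the first single-change step, and it shows that the read-out responds to the group at this carbon. Nothing measured on these compounds accounts for the step.

Going by these compounds, whether an unsubstituted amino group, a diethylamino group or a chlorine atom at this carbon would read higher or lower remains open. Also open, on these data alone, is whether the same exchange gives a similar step with a different chain length.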